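A few compounds are considered here, and "the series" means these few. Any claim that something is new, unique, unknown or untested is made for them only; others in the source may bear on it.

Values in a functional assay on HL-60 cells (Homo sapiens) for cytotoxicity, read by sulforhodamine B assay, with a stated time of 48 h (on this read-out lower numbers stand for stronger inhibition of growth and higher numbers for weaker inhibition of growth), so far
compound 1 `COc1ccc(C(=O)c2cc(OC)c(OC)c(OC)c2)c(OC)c1O` gives 23.5 nM
compound 2 `COc1ccc(C(=O)c2cc(OC)c(OC)c(OC)c2)c(OC)c1N` gives 33.1 nM
compound 3 `COc1ccc(C(=O)c2cc(OC)c(OC)c(OC)c2)c(OC)c1NC(C)=O` gives 3530 nM

Compound 2 stands close to its hydroxy counterpart (a 1.4-fold higher number from compound 1 to compound 2 (0.15 log units; within the scatter)) and far from its acetylated form (a 110-fold higher number from compound 2 to compound 3 (2.03 log units; beyond the scatter)). Compound 4 `COc1ccc(C(=O)c2cc(OC)c(OC)c(OC)c2)cc1N` follows from compound 2 by hydrogen in place of methoxy on an aromatic carbon and so carries hydrogen in place of methoxy on an aromatic carbon. Going by the values given here, no measured step removes a methoxy, so the series gives no direct size for this change. The measured steps alter only the hydroxy, amino or acetamido group, and the large ones involve the acetamido group alone. No step beyond the scatter is therefore expected in this assay, with wide uncertainty and no firm direction. The expected step is a 1.2-fold higher number from compound 2 to compound 4 (0.08 log units; within the scatter) and it remains an estimate. For compound 4 the estimate is 40 nM (expected range 10 nM to 200 nM).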

Compound 4, concentration for 50% growth inhibition: 30 nM
Compound 4: middle estimate off by 1.3-fold (0.12 log units), on the high side; the range from low to high includes it.
By their numbers in this assay, from the lowest: compounds 1, 4 and 2 (each within the scatter of the next); then compound 3.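

In this assay, going by these compounds alone, hydrogen in place of methoxy on the aromatic carbon ortho to the amino group gives a 1.1-fold lower number from compound 2 to compound 4 (0.04 log units; within the scatter), the first measured step at this position. With the amino group kept, compound 4 shows that this methoxy is not required for a value in this range. No measurement available here bears on the reason for this result.

Open, on these data alone, is whether an ethoxy group or a chlorine atom on this carbon would stay within the scatter. Also open, as far as these compounds go, is whether the same exchange holds alongside hydroxy or acetamido.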